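Swapping the aryl group on a thiosemicarbazone nitrogen

A few compounds are considered here, and "the series" means these few. Any claim that something is new, unique, unknown or untested is made for them only; others in the source may bear on it.

For the measured compounds named here, compound 2 `S=C(N/N=C/c1ccc2ccccc2n1)Nc1cccc(Cl)c1` is one of three compounds measured in a functional assay on HT-29 cells (Homo sapiens) for antiproliferative activity, read by sulforhodamine B assay, with a stated time of 72 h; on this read-out higher numbers stand for weaker inhibition and lower numbers for stronger inhibition. Compound 2 gives 48100 nM, the lowest of the two numbers obtained. Compound 3 `NC(=S)N/N=C/c1cc2ccccc2s1` gives 99200 nM in this assay, a gap from compound 2 that lies beyond the usual scatter. Compound 1 `COc1ccc(C)cc1NC(=S)N/N=C/c1ccc2ccccc2n1` returns only a limit of the assay, > 100000 nM, and not a number (the limit of > 100000 nM in this assay, at which 1 of the 3 values shown sits).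

Compound 4 `Fc1ccccc1NC(=S)N/N=C/c1ccc2ccccc2n1` differs from compound 2 at one place: 2-fluorophenyl in place of 3-chlorophenyl on an amide-type nitrogen. Going by the values given here, no pair of measured compounds shows an exchange of this kind, so there is no measured step to set its size. Compound 1 carries a different aryl group on the same nitrogen as compound 2 and reaches only the limit, which leaves the effect of changing this aryl group uncertain. The writer expects the step from compound 2 to compound 4 to be small or to lean toward weaker inhibition, estimated as a 1.5-fold higher number from compound 2 to compound 4 (0.16 log units; within the scatter). Compound 4 is accordingly estimated at 70000 nM, with an expected range from 25000 nM to 150000 nM.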

Compound 4, half-maximal inhibitory concentration: > 100000 nM
Compound 4: a limit, no number (the forecaster's own chance of this, stated with the estimate: 35%); at least 1.4-fold (0.15 log units) between middle value and limit.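

In this assay, for the compounds shown here, exchanging 3-chlorophenyl for 2-fluorophenyl on the amide-type nitrogen gives the first measured step at this position, an at least 2.0-fold higher number from compound 2 to compound 4 (0.31 log units; beyond the scatter). Compound 4 gives > 100000 nM, which is a limit of the assay and not a number. The step therefore shows that inhibition at this nitrogen can be lost with a change of aryl group alone, though only a lower bound on its size can be read, and of the aryl compounds shown only compound 2 returns a number: the limit of > 100000 nM in this assay, at which 2 of the 4 values shown sit.

The compounds shown leave open whether the halogen or its place on the ring matters, as 3-fluorophenyl and 2-chlorophenyl would tell. On these data alone, how plain phenyl or an ethyl chain on this nitrogen would read also remains open.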